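A few compounds are considered here, and "the series" means these few. Any claim that something is new, unique, unknown or untested is made for them only; others in the source may bear on it.

Notes on the series. In a functional assay with Alpha-1B adrenergic receptor (Homo sapiens) as the target, read by calcium flux (a higher number here means a larger maximal response, a lower number a smaller maximal response), compound 1 `Cc1n[nH]c(-c2ccccc2NCC2=NCCN2)n1` gives 0%, compound 2 `c1ccc(-c2nc[nH]n2)c(NCC2=NCCN2)c1` gives 100%, and compound 3 `Cn1ccnc1-c1ccccc1NCC1=NCCN1` gives 104%. Compound 3 holds the highest of the three numbers, though its separation from compound 2 lies within the scatter, while its separation from compound 1 is large. The two steps out of compound 1 were both large: a number 100 percentage points higher from compound 1 to compound 2 (beyond the scatter) and a number 104 percentage points higher from compound 1 to compound 3 (beyond the scatter). The step between the two high numbers was small: a number 4 percentage points higher from compound 2 to compound 3 (within the scatter).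

Compound 4 `Cn1nccc1-c1ccccc1NCC1=NCCN1` is not yet measured in this assay. It differs from compound 3 by 1-methyl-1H-pyrazol-5-yl in place of 1-methyl-1H-imidazol-2-yl on an aromatic carbon. Going by the values given here, the one comparable exchange of the five-membered ring on this aromatic carbon, from compound 2 to compound 3, stayed within the scatter, so the same is expected here, with the caveat that compound 1 shows a ring change on this carbon can also remove the response. For compound 4 the expected step is a number 19 percentage points lower from compound 3 to compound 4 (beyond the scatter), and the estimated value is 85%, with a range from 30% to 115%.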

Compound 4, largest response reached (reported as maximal response), in percent of the reference or control that the assay uses: 0%
Compound 4: middle estimate off by 85 percentage points, on the high side, outside the stated range (below it).
By their numbers in this assay, from the lowest: compounds 1 and 4 (each within the scatter of the next); then compounds 2 and 3 (each within the scatter of the next).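

In this assay, the exchange of 1-methyl-1H-imidazol-2-yl for 1-methyl-1H-pyrazol-5-yl gives a number 104 percentage points lower from compound 3 to compound 4 (beyond the scatter), although both groups have the same heavy atoms, the same hydrogen-bond counts and no net charge, so at this aromatic carbon the way the ring atoms are joined can decide the response on its own. Against the triazole of the high pair the result is a number 100 percentage points lower from compound 2 to compound 4 (beyond the scatter), while the comparison with the other silent compound gives no change at the digits printed from compound 1 to compound 4 (within the scatter), so the four compounds fall into two groups that the counted features of these rings do not separate. Nothing measured on these compounds accounts for the loss of response.

Still open, going by these compounds, is whether a 1H-pyrazol-5-yl without the methyl would bring the response back, as the triazole without its methyl does in compound 2. Also open, on these data alone, is how a 1-methyl-1H-pyrazol-3-yl or a plain phenyl would read at this carbon.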